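This account rests on a few compounds, and the source may have more. Where it says the series, first, only, none or still open, it means among the compounds named here.

Working notes on the series.

Of the compounds shown here, two of the set have numbers so far. Compound 1 `CN(C)c1cccc(C(c2ccc(F)cc2)N2CCCCC2)c1O` reaches only a limit in an assay for inhibition of protein disulfide-isomerase (Homo sapiens), with a stated time of 1 h (a higher number here means a weaker inhibitor, a lower number a stronger inhibitor), where compound 1 gives > 30000 nM; this is a limit of the assay, not a measured number. For the measured compounds named here, compound 2 `Cc1ccc(C(Nc2ccccn2)c2ccc3cccnc3c2O)cc1` is the one compound with a true value: in this assay compound 2 gives 460 nM. Compound 2 therefore stands as the only number shown, the other entry being (the limit of > 30000 nM in this assay, at which 1 of the 2 values shown sits), so no ordering among measured compounds can be drawn and no step between measured compounds is known.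

Compound 3 `Oc1c(C(Nc2ccccn2)c2c(Cl)cccc2Cl)ccc2cccnc12` is not yet measured. It differs from compound 2 in one place: 2,6-dichlorophenyl in place of 4-methylphenyl on a saturated chain carbon bound to an aromatic carbon and a nitrogen on an aromatic ring. Going by the values given here, with no measured step of comparable kind to lean on, the change is expected to shift the reading little, none beyond the usual scatter in either direction. The expected step from compound 2 to compound 3 is a 1.3-fold higher number from compound 2 to compound 3 (0.12 log units; within the scatter). For compound 3 the estimate in this assay is 600 nM, expected to fall between 150 nM and 2500 nM.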

Compound 3, half-maximal inhibitory concentration: 1890 nM
Beside the measured number, compound 3's estimate is 3.2-fold (0.50 log units) below it; the measured number falls inside the stated range.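

For the compounds shown here, this is the first measured step, and it shows that the aryl group on a saturated chain carbon bound to an aromatic carbon and a nitrogen on an aromatic ring is not a silent place in this assay (a 4.1-fold higher number from compound 2 to compound 3 (0.61 log units; beyond the scatter)). The exchange of 4-methylphenyl for 2,6-dichlorophenyl gives a weaker inhibitor, yet compound 3 still returns a true number rather than a limit, so this place tolerates the change in part and does not lose the reading altogether. Going by these compounds alone, nothing measured so far accounts for the size of this step.

Within the data shown here, the single step cannot separate the loss of the methyl group from the arrival of the two chlorine atoms, nor can it separate the number of chlorine atoms from where they sit, and a plain phenyl or a 4-chlorophenyl at this place would be needed to pull these apart. Compound 1 remains a limit of the assay (> 30000 nM) and differs from the others in more than one place, so it leaves open how the rest of the core contributes.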